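Chloro in place of methylsulfanyl: cytotoxicity on Vero cells

This account rests on a few compounds, and the source may have more. Where it says the series, first, only, none or still open, it means among the compounds named here.

Compound 1 `OC[C@@]12C[C@@H]1[C@@H](n1cnc3c(NC(C4CCC4)C4CCC4)nc(Cl)nc31)[C@H](O)[C@@H]2O`: 28000 nM
Compound 2 `CSc1nc(N[C@@H](C2CC2)C(C)(C)O)c2ccn([C@H]3[C@H](O)[C@H](O)[C@]4(CO)C[C@H]34)c2n1`: > 100000 nM

Of the compounds shown here, two have been measured in an ADME assay on Vero 76 cells (Chlorocebus sabaeus) for cytotoxicity, read by neutral red uptake; a higher number here means that more compound is tolerated, a lower number that less compound is tolerated. Compound 1 `OC[C@@]12C[C@@H]1[C@@H](n1cnc3c(NC(C4CCC4)C4CCC4)nc(Cl)nc31)[C@H](O)[C@@H]2O` gives 28000 nM. For compound 2 `CSc1nc(N[C@@H](C2CC2)C(C)(C)O)c2ccn([C@H]3[C@H](O)[C@H](O)[C@]4(CO)C[C@H]34)c2n1` the assay returns only a limit, > 100000 nM, so its position is known only as a limit, the one at which one of the two values sits (the limit of > 100000 nM in this assay, at which 1 of the 2 values shown sits). Among the measured compounds shown here, no pair of measured compounds differs in a single place, so no measured step is available.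

Compound 3 `CC(C)(O)[C@@H](Nc1nc(Cl)nc2c1ccn2[C@H]1[C@H](O)[C@H](O)[C@]2(CO)C[C@H]12)C1CC1` has not yet been measured. It differs from compound 2 by chloro in place of methylsulfanyl on an aromatic carbon. For the measured compounds named here, with no measured step of this kind to lean on, the expected change from compound 2 to compound 3 is an at least 1.2-fold lower number from compound 2 to compound 3 (0.09 log units; that floor lies within the scatter), a modest fall that may not exceed the usual scatter. Compound 3 is therefore estimated at 80000 nM, with a range from 25000 nM to 200000 nM.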

Compound 3, half-maximal cytotoxic concentration: 63000 nM
Estimate against measurement, compound 3: 1.3-fold (0.10 log units) above, within the range that was stated.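

In this assay, the change from methylsulfanyl to chloro on the aromatic carbon between two ring nitrogen atoms now has a measured step: an at least 1.5-fold lower number from compound 2 to compound 3 (0.20 log units; that floor lies within the scatter). Chloro at this position gives a figure that can be read as a number, with compound 3 at 63000 nM. The step has only a floor and no fixed size, because compound 2 is known only as a limit of the assay: the limit of > 100000 nM in this assay, at which 1 of the 3 values shown sits.

Going by these compounds, the true size of this change remains open, including whether it goes beyond the scatter at all. Also open, on these data alone, are how a methoxy group or an amine at this position would compare, and whether the same change would give a similar step on the core of compound 1.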